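The source may hold more compounds than are shown below. What is called first, only, known or untested is meant among the compounds shown, and "the series" means these compounds.

Measured in an assay on brain for binding affinity to Neuronal acetylcholine receptor; alpha4/beta2 (Rattus norvegicus), read by radioligand binding; a lower number here means a stronger inhibitor, a higher number a weaker inhibitor:

Compound 1 `Clc1cncc(OC[C@@H]2CCN2)c1` gives 0.042 nM.
Compound 2 `Cc1cncc(OC[C@@H]2CCN2)c1` gives 0.047 nM.
Compound 3 `c1ccc(-c2cncc(OC[C@@H]3CCN3)c2)cc1` gives 0.046 nM.

Compound 1 shows the lowest of the three numbers, but the gaps to the others are small: a 1.1-fold higher number from compound 1 to compound 2 (0.05 log units; within the scatter) and a 1.1-fold higher number from compound 1 to compound 3 (0.04 log units; within the scatter), and between the other two a 1.0-fold lower number from compound 2 to compound 3 (0.01 log units; within the scatter). All three values sit within the usual scatter of one another, so none of these compounds can be set apart from the others in this assay.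

Compound 4 `Clc1cc(OC[C@@H]2CCN2)cnc1Cl` is compound 1 with one further change: chloro in place of hydrogen on an aromatic carbon. The three measured steps all swap the group at one and the same position of the core and leave the number essentially unchanged, whatever the size of the group there. None of them touches the position now in question, next to the ring nitrogen and ortho to the existing chloro group, so they bear on the new step only loosely: they show that this core tolerates variation at a neighbouring position, not what happens at this one. On that basis the step from compound 1 to compound 4 is expected to be modest, estimated as a 2.4-fold higher number from compound 1 to compound 4 (0.38 log units; beyond the scatter), and a wide range is kept open. For compound 4 the expected value in this assay is 0.1 nM, within a range from 0.03 nM to 0.5 nM.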

Compound 4, inhibition constant: 0.023 nM
For compound 4 the middle estimate is 4.3-fold (0.64 log units) above the measured one, and the stated range ends above it.
By their numbers in this assay, from the lowest: compounds 4, 1, 3 and 2 (each within the scatter of the next, the first and the last beyond it).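

In this assay, putting a chloro group in place of hydrogen on the aromatic carbon next to the ring nitrogen, ortho to the existing chloro group, gives a 1.8-fold lower number from compound 1 to compound 4 (0.26 log units; within the scatter). Among these compounds, this is the first look at this position, as the earlier steps only exchanged chloro, methyl and phenyl at another place on the core, and it shows that hydrogen here can give way to chloro without a difference that stands out from the ordinary spread of repeat measurements. Since the step lies within that spread, it shows tolerance rather than a real gain in binding, and no measurement shown here offers an explanation for the result.

From the compounds shown here alone, at this position only hydrogen and chloro are seen, so it remains open whether a larger or different group, such as phenyl, an amine or a carboxylic acid, would be accepted as well. Going by these compounds, it is also open whether a chloro group here would give a similar result with methyl or phenyl in place of the existing chloro group, as in the cores of compound 2 and compound 3.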